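Vinyl sulfone series: indolyl in place of methoxyphenyl

The source may report more compounds than this note shows. Statements on the series, on what has been measured and on what is new or still open speak of the compounds shown alone.

Measured compounds:
compound 1, `COc1ccccc1/C=C(\C(=O)c1ccc(Br)cc1)S(=O)(=O)c1ccc(C)cc1`, 1000 nM
compound 2, `COc1ccccc1/C=C(\C(=O)c1ccc(Cl)cc1)S(=O)(=O)c1ccc(C)cc1`, 1000 nM
compound 3, `COc1ccccc1/C=C(\C(=O)c1ccc(Br)cc1)S(=O)(=O)Cc1ccc(F)cc1`, 25000 nM

In a functional assay on DU-145 cells (Homo sapiens) for inhibition, read by trypan blue exclusion, with a stated time of 96 h (on this read-out higher numbers stand for weaker inhibition of growth and lower numbers for stronger inhibition of growth), compound 1 gives 1000 nM. It stands level with compound 2, the two together giving the lowest numbers of the three; no change at the digits printed from compound 1 to compound 2 (within the scatter), from the change of chloro in place of bromo on an aromatic carbon. The far end is compound 3, reached by a 25-fold higher number from compound 1 to compound 3 (1.40 log units; beyond the scatter) after 4-fluorobenzyl in place of 4-methylphenyl on a sulfonyl sulfur.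

Compound 4, `Cc1ccc(S(=O)(=O)/C(=C/c2c[nH]c3ccccc23)C(=O)c2ccc(Br)cc2)cc1`, is not yet measured in this assay. It differs from compound 1 by 1H-indol-3-yl in place of 2-methoxyphenyl on a double-bonded chain carbon bound to a double-bonded chain carbon.

Neither measured step touches this position: one changes the halogen on the aroyl ring, the other the group on the sulfonyl sulfur, and both keep the 2-methoxyphenyl. So nothing measured bears on the step to compound 4, and no direction can be drawn from the series. The expectation for compound 4 is therefore taken as close to compound 1, with a wide range on either side, the step of a 1.3-fold lower number from compound 1 to compound 4 (0.10 log units; within the scatter) being an estimate only. Compound 4 is estimated at 800 nM, between 150 nM and 5000 nM.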

Compound 4, concentration for 50% growth inhibition: 10000 nM
Estimate against measurement, compound 4: 13-fold (1.10 log units) below; the measured number lies above the stated range.
By their numbers in this assay, from the lowest: compounds 1 and 2 (each within the scatter of the next); then compound 4; then compound 3.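

For the compounds shown here, this position, untouched by the earlier steps, does matter in this assay: 1H-indol-3-yl in place of 2-methoxyphenyl gives a 10-fold higher number from compound 1 to compound 4 (1.00 log units; beyond the scatter) and so weaker inhibition of growth. The group on the double-bonded chain carbon is therefore a real lever on this read-out, unlike the halogen on the aroyl ring, whose step no change at the digits printed from compound 1 to compound 2 (within the scatter) moved nothing. Nothing available explains the direction or size of this step.

Open, as far as these compounds go, is whether the hydrogen on the indole nitrogen or the ring exchange as a whole goes with the higher number, and a methyl on the indole nitrogen or a plain phenyl at this place would help to separate the two. Also open, from the compounds shown here alone, is whether any group here gives a lower number than the 2-methoxyphenyl of compound 1 does.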